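Halogen swap on the aryl ketone of the boron-bearing series

A few compounds are considered here, and "the series" means these few. Any claim that something is new, unique, unknown or untested is made for them only; others in the source may bear on it.

Of the compounds shown here, two have been measured in a functional assay on HCT-116 cells (Homo sapiens) for cytotoxicity, read by MTT assay, with a stated time of 48 h; on this read-out lower numbers stand for stronger inhibition and higher numbers for weaker inhibition. Compound 1 `O=C(/C=C/c1ccc2c(c1)B(O)OC2)c1cccnc1` gives 20500 nM in this assay. Compound 2 `O=C(/C=C/c1ccc2c(c1)B(O)OC2)c1ccc(F)cc1` gives 2800 nM in this assay. Among the measured compounds shown here, the single one-place step so far, a 7.3-fold lower number from compound 1 to compound 2 (0.86 log units; beyond the scatter), replaces pyridin-3-yl with 4-fluorophenyl on the carbonyl carbon. Compound 2 therefore holds the lowest number of the two, and its nearest neighbour, compound 1, sits a clear step above it.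

Compound 3 `O=C(/C=C/c1ccc2c(c1)B(O)OC2)c1ccc(Cl)cc1` differs from compound 2 by chloro in place of fluoro on an aromatic carbon, that is, on an aromatic carbon of a six-membered aromatic ring of carbon only, para to a large group. For the measured compounds named here, no measured step bears on this change: the only step in hand exchanges the whole ring on the carbonyl carbon and says nothing about one halogen for another at the same position. The expectation for compound 3 in this assay is therefore a step of a 1.4-fold lower number from compound 2 to compound 3 (0.15 log units; within the scatter), a small shift that may well stay within the scatter. Compound 3 is estimated at 2000 nM in this assay, with a range from 700 nM to 6000 nM.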

Compound 3, half-maximal inhibitory concentration: 9300 nM
For compound 3 the middle estimate is 4.7-fold (0.67 log units) below the measured one, and the stated range ends below it.
By their numbers in this assay, from the lowest: compound 2; then compound 3; then compound 1.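

In this assay, the place para to a large group on the six-membered aromatic ring of carbon only proves sensitive to the identity of the halogen: chloro in place of fluoro gives a 3.3-fold higher number from compound 2 to compound 3 (0.52 log units; beyond the scatter), so exchanging one heavy atom for another on an otherwise unchanged compound moves the number beyond the scatter. The gain over pyridin-3-yl therefore depends on the halogen carried by the phenyl ring, with 4-chlorophenyl giving a 2.2-fold lower number from compound 1 to compound 3 (0.34 log units; beyond the scatter), a smaller step than a 7.3-fold lower number from compound 1 to compound 2 (0.86 log units; beyond the scatter) seen with 4-fluorophenyl. No measured evidence is available on why fluoro and chloro differ at this position.

On these data alone, with only two halogens at this one place, it remains open whether the number follows any order across substituents, and where a bromo, methoxy or amino group, or an unsubstituted phenyl ring, would fall relative to compound 2 and compound 3. Also open, as far as these compounds go, is whether the difference between fluoro and chloro would persist on a core changed elsewhere, for instance at the boron-bearing part of the shared core.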